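Chlorophenyl in Place of Methylphenyl on the Amide Nitrogen

A few compounds are considered here, and "the series" means these few. Any claim that something is new, unique, unknown or untested is made for them only; others in the source may bear on it.

Going by the values given here, compound 2 `Cc1ccc(NC(=O)c2nnc(COc3ccc(CCC(=O)O)cc3)s2)cc1` gives 4300 nM in a functional assay on CHO cells for agonist activity at Free fatty acid receptor 1 (Homo sapiens), read by calcium flux (on this read-out lower numbers stand for an effect already at smaller amounts and higher numbers for an effect only at larger amounts of compound), and is the only compound with a number among the values shown. Compound 1 `COc1ccc(NC(=O)c2nnc(COc3ccc(CCC(=O)O)cc3)s2)cc1` gives > 10000 nM in this assay, which is a limit of the assay rather than a number. Among the compounds with values here, the one measured step, an at least 2.3-fold lower number from compound 1 to compound 2 (0.36 log units; beyond the scatter), shows that changing the group on the amide-type nitrogen can move this read-out. Compound 3 `O=C(O)CCc1ccc(OCc2nnc(C(=O)Nc3cccc(Cl)c3)s2)cc1` differs from compound 2 by 3-chlorophenyl in place of 4-methylphenyl on an amide-type nitrogen. Within the data shown here, no measured step covers this exchange, so only a small expected step is assumed: a 1.4-fold lower number from compound 2 to compound 3 (0.16 log units; within the scatter). For compound 3 the estimate is 3000 nM, within 800 nM to 12000 nM.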

Compound 3, half-maximal effective concentration: 10600 nM
Estimate against measurement, compound 3: 3.5-fold (0.55 log units) below, within the range that was stated.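

In this assay, 3-chlorophenyl in place of 4-methylphenyl on the amide-type nitrogen gives a 2.5-fold higher number from compound 2 to compound 3 (0.39 log units; beyond the scatter) and so shows that a change at this position can also raise the number, not only lower it. Compound 1 carries a limit rather than a number, so its step to compound 3 cannot be read: the limit of > 10000 nM in this assay, at which 1 of the 3 values shown sits.

This exchange alters both the atom on the ring and where it sits, so the two effects cannot be told apart. 4-Chlorophenyl and 3-methylphenyl would separate them, and these groups are not among the compounds shown.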